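Swapping Fluoro for Nitro on the Aryl Ring

This account rests on a few compounds, and the source may have more. Where it says the series, first, only, none or still open, it means among the compounds named here.

Of the compounds shown here, three built on one shared core have been tested in an ADME assay on NIH3T3 cells (Mus musculus) for cytotoxicity, read by MTT assay, with a stated time of 24 h; on this read-out lower numbers stand for stronger inhibition and higher numbers for weaker inhibition. Compound 1 `Cn1cnnc1SCC(=O)N/N=c1/scc(-c2ccc([N+](=O)[O-])cc2)n1-c1ccccc1` gives 133 ug/mL, and compound 2 `O=C(CSc1ncccn1)N/N=c1/scc(-c2ccc([N+](=O)[O-])cc2)n1-c1ccccc1` gives 193 ug/mL; the step between them is a 1.5-fold higher number from compound 1 to compound 2 (0.16 log units; within the scatter). Compound 3 `O=C(CSc1nnnn1-c1ccccc1)N/N=c1/scc(-c2ccc(F)cc2)n1-c1ccccc1` gives 207 ug/mL in this assay, a number that lies within the usual scatter of both compound 1 and compound 2. Compound 4 `O=C(CSc1nnnn1-c1ccccc1)N/N=c1/scc(-c2ccc([N+](=O)[O-])cc2)n1-c1ccccc1` differs from compound 3 by nitro in place of fluoro on an aromatic carbon. Within the data shown here, no measured step bears on this exact change: the single measured step alters the group on sulfur and stays within the scatter, so nothing beyond the scatter is expected here either. The expected step is a 1.1-fold lower number from compound 3 to compound 4 (0.04 log units; within the scatter). Compound 4 is therefore estimated at 190 ug/mL in this assay, with a range from 100 ug/mL to 360 ug/mL.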

Compound 4, half-maximal inhibitory concentration: 14.3 ug/mL
Beside the measured number, compound 4's estimate is 13-fold (1.12 log units) above it, and the stated range ends above it.
By their numbers in this assay, from the lowest: compound 4; then compounds 1, 2 and 3 (each within the scatter of the next).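

On the aryl ring, 4-nitrophenyl in place of 4-fluorophenyl gives a 14-fold lower number from compound 3 to compound 4 (1.16 log units; beyond the scatter) in this assay and so shows that this position can shift the number well beyond the scatter. With nitro kept, the group on sulfur also counts: 1-phenyl-1H-tetrazol-5-yl gives a 13-fold lower number from compound 2 to compound 4 (1.13 log units; beyond the scatter) and a 9.3-fold lower number from compound 1 to compound 4 (0.97 log units; beyond the scatter) even though the earlier step on sulfur stayed within the scatter. Nothing shown here explains these drops. Open, on these data alone, is whether an amine or a carboxylic acid on this carbon would behave like nitro, and whether fluoro in place of nitro would also raise the number for compound 1 and compound 2.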